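Amide variation and tolerated concentration in the series

The source may hold more compounds than are shown below. What is called first, only, known or untested is meant among the compounds shown, and "the series" means these compounds.

Working notes on cytotoxicity. Among the compounds with values here, the read-out throughout is an ADME assay on Huh-7 cells (Homo sapiens) for cytotoxicity, read by MTT assay, with a stated time of 72 h (a higher number here means that more compound is tolerated, a lower number that less compound is tolerated), and every value so far sits at the upper limit of that assay. Compound 1 `CCOC(=O)c1sc2nc(-c3ccco3)cc(C(F)(F)F)c2c1N` reaches only the limit of > 20000 nM in this assay. Compound 2 `CCOC(=O)c1oc2nc(-c3cccs3)cc(C(F)(F)F)c2c1N` likewise reaches only the limit of > 20000 nM in this assay. Within the data shown here, compound 3 `CN(C)C(=O)c1sc2nc(-c3ccccc3)cc(C(F)(F)F)c2c1N` again reaches only the limit of > 20000 nM in this assay, so its standing is a limit and not a number, and no compound can be set apart from another on these values; what is shared is the limit of > 20000 nM in this assay, at which 3 of the 3 values shown sit.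

The next compound, compound 4 `Nc1c(C(=O)N2CCc3sccc3C2)sc2nc(-c3ccccc3)cc(C(F)(F)F)c12`, differs from compound 3 in one place: a group of 9 heavy atoms (7 carbon, 1 nitrogen, 1 sulfur; one five-membered aromatic ring with 1 hetero atom, one six-membered non-aromatic ring with 1 hetero atom) in place of a group of 3 heavy atoms (2 carbon, 1 nitrogen; no ring), on a carbonyl carbon. Among the measured compounds shown here, no measured step involves a change of this kind, so nothing measured speaks for or against a move.

The step from compound 3 to compound 4 is expected to be a number no higher from compound 3 to compound 4 (the limit leaves the size open), that is none beyond the scatter. Compound 4 is expected to give 20000 nM in this assay, with a range from 8000 nM to 50000 nM, most likely again reported only as the limit.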

Compound 4, half-maximal cytotoxic concentration: > 20000 nM
Compound 4: no number, only a limit (the forecaster's own chance of this, stated with the estimate: 70%); the middle value lies on the limit itself.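

Compound 3 and compound 4 both stand only at a limit, not at a number, in this assay, so the replacement of dimethylamino on the carbonyl carbon gives no readable step: the limit of > 20000 nM in this assay, at which 4 of the 4 values shown sit. The compounds shown leave open whether any change to the amide, or elsewhere on the shared core, lowers the tolerated concentration at all.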